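Swapping a fused aromatic bicycle for a partly saturated one

The source may hold more compounds than are shown below. What is called first, only, known or untested is meant among the compounds shown, and "the series" means these compounds.

Three analogues of one amide series have been measured in a physicochemical assay for lipophilicity, using the shake flask method, measured as octanol-water partition, at pH 7.4; on this read-out lower numbers stand for lower lipophilicity and higher numbers for higher lipophilicity. Compound 1 `CC(=O)N[C@@H]1CCC[C@H](C(=O)Nc2cc(-c3cnc(C)n3C(C)C)ccn2)C1` gives 1.9. Compound 2 `CC(=O)N[C@@H]1CCC[C@H](C(=O)Nc2cc(-c3cnn4c3CCCC4)c(F)cn2)C1` gives 2.9. Compound 3 `CC(=O)N[C@@H]1CCC[C@H](C(=O)Nc2cc(-c3cnc4ccccn34)c(Cl)cn2)C1` gives 3. Compound 3 and compound 2 cannot be told apart, since their values lie within the usual scatter of this assay, whereas compound 1 sits clearly below compound 3, beyond the scatter.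

Compound 4 `CC(=O)N[C@@H]1CCC[C@H](C(=O)Nc2cc(-c3cnc4n3CC(C)(C)C4)c(Cl)cn2)C1` is not yet measured. It differs from compound 3 in one place: a group of 10 heavy atoms (8 carbon, 2 nitrogen; one five-membered non-aromatic ring with 1 hetero atom, one five-membered aromatic ring with 2 hetero atoms) in place of a group of 9 heavy atoms (7 carbon, 2 nitrogen; one five-membered aromatic ring with 2 hetero atoms, one six-membered aromatic ring with 1 hetero atom), on an aromatic carbon. The six-membered aromatic ring with one nitrogen leaves, and a five-membered non-aromatic ring with one hetero atom enters, so the fused bicycle loses part of its aromatic character while gaining one heavy atom.

Going by the values given here, no measured pair shows this exact exchange, so the expectation rests on the spread of the three numbers. Because compound 1, whose core holds only a five-membered aromatic ring, gives 1.9, a partly saturated bicycle is expected to land between compound 1 and compound 3. The estimated step of a number 0.60 log units lower from compound 3 to compound 4 (beyond the scatter) is a moderate decrease, beyond the scatter. Compound 4 is therefore expected to give about 2.4, within a range from 1.8 to 3.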

Compound 4, distribution coefficient: 3.6
Estimate against measurement, compound 4: 1.20 log units below; measured number above the stated range.
By their numbers in this assay, from the lowest: compound 1; then compounds 2 and 3 (each within the scatter of the next); then compound 4.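

Going by these compounds alone, at this position, on an aromatic carbon ortho to a chloro group, the first direct exchange of one fused bicycle for another can now be read. In this assay, replacing the six-membered aromatic ring with 1 hetero atom by a five-membered non-aromatic ring with 1 hetero atom gives a number 0.60 log units higher from compound 3 to compound 4 (beyond the scatter), so in this pair, losing an aromatic ring does not go with a lower number, even though the counts of hydrogen-bond donors and acceptors stay the same. No measurement here explains this rise.

Still open, going by these compounds, is whether the rise follows the change of ring or the added heavy atom, as this single pair cannot separate the two. Also open, on these data alone, is how a non-aromatic ring carrying a hydroxyl group or an amine would read at this position.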